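The compounds below may be only part of what the source reports. "The series", "measured", "known", "first", "only" and "open" are said of these compounds alone.

Measured so far:
compound 1 `Cc1nc(-c2cccc(CNc3ccc4[nH]nc(C(=O)O)c4c3)c2O)sc1C`: 3.8 10^-6 cm/s
compound 2 `CN(C)c1noc(-c2cccc(CNc3ccc4[nH]nc(C(=O)O)c4c3)c2Cl)n1`: 0.7 10^-6 cm/s

In an ADME assay on MDCK cells (Canis lupus familiaris) for permeability, in the apical to basolateral direction (on this read-out lower numbers stand for lower permeability and higher numbers for higher permeability), compound 1 gives 3.8 10^-6 cm/s, the higher of the two numbers, while compound 2 gives 0.7 10^-6 cm/s, a gap beyond the usual scatter. These two compounds differ in several places, so their values show only that gap. Compound 3 `CC(C)c1coc(-c2cccc(CNc3ccc4[nH]nc(C(=O)O)c4c3)c2O)n1` has not yet been measured. It differs from compound 1 in one place: 4-isopropyl-1,3-oxazol-2-yl in place of 4,5-dimethyl-1,3-thiazol-2-yl on an aromatic carbon. Among the measured compounds shown here, no measured pair follows a comparable change, so only a small step, if any, is expected, and a 1.3-fold lower number from compound 1 to compound 3 (0.10 log units; within the scatter) is estimated to stay within the scatter. Compound 3 is expected to give about 3 10^-6 cm/s, with a likely range from 1 10^-6 cm/s to 8 10^-6 cm/s.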

Compound 3, apparent permeability: 3.6 10^-6 cm/s
Compound 3: the middle estimate sits 1.2-fold (0.08 log units) below what was measured; measured number inside the range.
By their numbers in this assay, from the lowest: compound 2; then compounds 3 and 1 (each within the scatter of the next).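

In this assay, 4-isopropyl-1,3-oxazol-2-yl in place of 4,5-dimethyl-1,3-thiazol-2-yl gives a 1.1-fold lower number from compound 1 to compound 3 (0.02 log units; within the scatter). So on this aromatic carbon, ortho to a hydroxy group, one five-membered aromatic ring with 2 hetero atoms can stand in for the other without a step beyond the scatter. Nothing measured here gives a reason for this. As far as these compounds go, since the ring atoms and the alkyl groups change together, their separate contributions remain open. So does whether a different kind of group here, such as an amine or a carboxylic acid, would leave the number in the same place.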